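Swapping chloro for bromo on a second core

A few compounds are considered here, and "the series" means these few. Any claim that something is new, unique, unknown or untested is made for them only; others in the source may bear on it.

Compound 1 `O=C1C(=O)N(CN2CCN(c3ccnc4cc(Cl)ccc34)CC2)c2cccc(Cl)c21` in an ADME assay on 184B5 cells (Homo sapiens) for cytotoxicity, read by sulforhodamine B assay, with a stated time of 48 h (on this read-out higher numbers stand for weaker inhibition of growth and lower numbers for stronger inhibition of growth), gives 77700 nM. Compound 2 `O=C1C(=O)N(CN2CCN(c3ccnc4cc(Cl)ccc34)CC2)c2cccc(Br)c21` carries bromo in place of chloro on an aromatic carbon; in this assay compound 2 gives 49000 nM, and the step of a 1.6-fold lower number from compound 1 to compound 2 (0.20 log units; within the scatter). Compound 3 `NC(=S)N/N=C1/C(=O)N(CN2CCN(c3ccnc4cc(Cl)ccc34)CC2)c2cc(Cl)ccc21` has a different core; how it differs from the core of compound 1 is not broken down here. In this assay compound 3 gives 41300 nM. Compound 4 `NC(=S)N/N=C1/C(=O)N(CN2CCN(c3ccnc4cc(Cl)ccc34)CC2)c2cc(Br)ccc21`, not yet measured, carries bromo in place of chloro on an aromatic carbon. This is the same kind of change as from compound 1 to compound 2, though the place differs: there the ring carbon was ortho to a fused ring and meta to a fused ring, here it is meta to a fused ring and para to a fused ring. Because the earlier step of a 1.6-fold lower number from compound 1 to compound 2 (0.20 log units; within the scatter) stayed within the scatter, compound 4 is expected to show a similarly small step, estimated as a 1.2-fold lower number from compound 3 to compound 4 (0.07 log units; within the scatter). The value of compound 4 is estimated at 35000 nM, likely between 15000 nM and 80000 nM.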

Compound 4, concentration for 50% growth inhibition: 13100 nM
The estimate for compound 4 lay 2.7-fold (0.43 log units) above the measured number; measured number outside the range, below it.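

In this assay, bromo in place of chloro on an aromatic carbon gives a 3.2-fold lower number from compound 3 to compound 4 (0.50 log units; beyond the scatter), a step that stands clear of the usual scatter, unlike the step on the core of compound 1. Even so, the two steps run the same way and their gap does not exceed what repeated measurements would produce: the same change on two cores in this assay, a 1.6-fold lower number (0.20 log units; within the scatter) from compound 1 to compound 2 and a 3.2-fold lower number (0.50 log units; beyond the scatter) from compound 3 to compound 4, 2.0-fold (0.30 log units) apart, within the scatter of two such steps. The change therefore lowers the number on both cores shown, but these two pairs cannot show that the size of the step depends on the core, or predict it on any further core.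

The compounds shown leave open how a fluoro group, a methoxy group, an amine or a carboxylic acid on that aromatic carbon would read in this assay.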